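The source may report more compounds than this note shows. Statements on the series, on what has been measured and on what is new or still open speak of the compounds shown alone.

The measured compounds:

Compound 1, `O=C1Nc2ccccc2C1(c1ccc(O)cc1)c1ccc(F)cc1`, > 1000 nM.
Compound 2, `O=C1Nc2ccccc2C1(c1ccc(O)cc1)C1CCCCCC1`, > 1000 nM.
Compound 3, `Cc1cc(C)c2c(c1)C(c1ccc(O)cc1)(c1ccc(F)cc1)C(=O)N2`, 209 nM.

In a functional assay on PC-3 cells (Homo sapiens) for cytotoxicity, read by WST assay, with a stated time of 72 h (a higher number here means a weaker inhibitor, a lower number a stronger inhibitor), the value of compound 1 is a limit of the assay, not a number. The value of compound 2 is likewise a limit. Going by the values given here, compound 3 gives the only number of the three in this assay, with its 209 nM. The step that the two limits leave unreadable from compound 1 to compound 2 is the change (cycloheptyl in place of 4-fluorophenyl on a saturated ring carbon), and its size cannot be read because the limit of > 1000 nM in this assay, at which 2 of the 3 values shown sit, holds both ends.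

Compound 4, `Cc1cc(C)c2c(c1)C(c1ccc(O)cc1)(C1CCCCCC1)C(=O)N2`, is yet to be measured. It carries the same change to compound 3, namely (cycloheptyl in place of 4-fluorophenyl on a saturated ring carbon). How the core of compound 3 differs from the core of compound 1 is not broken down here.

For compound 4 the expected step in this assay is a 2.9-fold higher number from compound 3 to compound 4 (0.46 log units; beyond the scatter), and it rests on little, since the earlier step from compound 1 to compound 2 is unreadable. The estimate for compound 4 in this assay is therefore a broad one, 600 nM, with a range from 200 nM to 2000 nM.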

Compound 4, half-maximal inhibitory concentration: > 1000 nM
Compound 4: a limit, no number; the forecaster's own chance of this, stated with the estimate: 40%; at least 1.6-fold (0.22 log units) between middle value and limit.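

In this assay, cycloheptyl in place of 4-fluorophenyl on the core of compound 3 gives an at least 4.7-fold higher number from compound 3 to compound 4 (0.67 log units; beyond the scatter), so on this core the change clearly weakens the compound, by a step beyond the scatter. Compound 4 gives > 1000 nM, which is a limit of the assay and not a number. The result does not show that the change costs the same on both cores, because the step from compound 1 to compound 2 cannot be read, with both of its ends held by one limit: the limit of > 1000 nM in this assay, at which 3 of the 4 values shown sit.

The compounds shown carry only 4-fluorophenyl and cycloheptyl at this place, so it stays open whether cyclopentyl, or an amine or a carboxylic acid, on that saturated ring carbon would keep the number of compound 3. Also open, going by these compounds, are how far compound 4 really lies past its limit and how the change would read on a third core.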